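Adding a second methoxy to the anilide of compound 2

The source may hold more compounds than are shown below. What is called first, only, known or untested is meant among the compounds shown, and "the series" means these compounds.

Measured so far:
compound 1 `Cc1cccc(OC(=O)c2cc([N+](=O)[O-])cc([N+](=O)[O-])c2)c1` gives 6 nM
compound 2 `COc1ccc(NC(=O)c2cc([N+](=O)[O-])cc([N+](=O)[O-])c2)cc1` gives 34 nM

Both compounds were tested in an assay on isolated protein for inhibition of Polyunsaturated fatty acid 5-lipoxygenase (Homo sapiens), read by fluorescence, with a stated time of 10 min; a higher number here means a weaker inhibitor, a lower number a stronger inhibitor. They share a dinitrobenzoyl core and differ in what the carbonyl is joined to: in compound 1 an ester to a methyl-substituted phenol, in compound 2 an amide to a methoxy-substituted aniline. Among these two numbers compound 2 stands highest, so it is the weaker inhibitor of the pair, and the gap to compound 1 is beyond the usual scatter of repeated measurements.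

The next compound to be considered is compound 3 `COc1ccc(NC(=O)c2cc([N+](=O)[O-])cc([N+](=O)[O-])c2)cc1OC`, which is not yet measured. The change from compound 2 to compound 3 is methoxy in place of hydrogen on an aromatic carbon. For the measured compounds named here, no measured pair in this set shows the effect of such a change, so there is nothing here to anchor a direction. Going by the values given here, with the anilide kept and only one small group added, the step of a 1.2-fold higher number from compound 2 to compound 3 (0.07 log units; within the scatter) is expected to be small, not beyond the scatter in either direction. On that basis compound 3 is expected to give about 40 nM in this assay, with a range from 15 nM to 110 nM.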

Compound 3, half-maximal inhibitory concentration: 1100 nM
Compound 3: middle estimate off by 28-fold (1.44 log units), on the low side, outside the stated range (above it).
By their numbers in this assay, from the lowest: compound 1; then compound 2; then compound 3.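

Placing one methoxy on an aromatic carbon of the anilide ring, ortho to a methoxy group and meta to a large group, gives in this assay a 32-fold higher number from compound 2 to compound 3 (1.51 log units; beyond the scatter), so compound 3 is a much weaker inhibitor than compound 2. For the compounds shown here, until now the set held no pair differing in one place, so it could not show how much this ring matters; this step shows that inhibition here can depend strongly on a single added group of only two heavy atoms, with no ring and no net charge. Nothing measured here explains why the number climbs so far.

The compounds shown leave open whether the loss belongs to the methoxy itself or would follow any group on this carbon, a question that a fluorine atom, a methyl or a hydroxyl in the same place could answer. They also leave open whether an ester in place of the amide of compound 3 would respond in the same way.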